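Hydroxyalkyl amide trimming on the shared core

A few compounds are considered here, and "the series" means these few. Any claim that something is new, unique, unknown or untested is made for them only; others in the source may bear on it.

Measured so far in a functional assay on MKN-45 cells (Homo sapiens) for antiproliferative activity, read by MTT assay, with a stated time of 72 h, tested at 10 uM; on this read-out lower numbers stand for less inhibition and higher numbers for more inhibition at the one concentration tested (going by the name of the read-out):
- compound 1 `CCn1cc(-c2ccc(F)cc2)c(=O)c2c(Nc3ccc(Oc4ccnc(NC(=O)C5CC5)c4)c(F)c3)nccc21`: 31.9%
- compound 2 `CC(O)C(=O)Nc1cc(Oc2ccc(Nc3nccc4[nH]cc(-c5ccc(F)cc5)c(=O)c34)cc2F)ccn1`: 67.3%

Compound 2 stands highest of the two numbers; its nearest neighbour is compound 1, which lies lower by a gap beyond the scatter. Among the compounds with values here, no step between measured compounds that differ in one place is available, so the two values show only that compound 2 inhibits more than compound 1 in this assay, without a single structural change to account for it.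

Compound 3 `O=C(CO)Nc1cc(Oc2ccc(Nc3nccc4[nH]cc(-c5ccc(F)cc5)c(=O)c34)cc2F)ccn1` is not yet measured. It differs from compound 2 by hydrogen in place of methyl on a saturated chain carbon bound to a carbonyl carbon and an oxygen on a saturated carbon. The 1-hydroxyethyl becomes hydroxymethyl; one carbon leaves, with no change to ring count, hydrogen-bond donors or acceptors.

With no measured step of this kind in the series, the expectation is a step of no more than the scatter, in either direction: the estimated step from compound 2 to compound 3 is a number 5.3 percentage points lower from compound 2 to compound 3 (within the scatter). Compound 3 is therefore expected to give about 62%, within a range of 45% to 78%.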

Compound 3, a percentage reported as inhibition, at one concentration (the size of the read-out at that concentration, not a potency): 63%
Compound 3: middle estimate off by 1 percentage points, on the low side; measured number inside the range.
By their numbers in this assay, from the lowest: compound 1; then compounds 3 and 2 (each within the scatter of the next).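

On the amide of the shared core, hydrogen in place of methyl on the saturated chain carbon bound to a carbonyl carbon and an oxygen on a saturated carbon gives, in this assay, a number 4.3 percentage points lower from compound 2 to compound 3 (within the scatter). This is the only one-place step in the compounds shown, and at the one concentration tested it does not separate 1-hydroxyethyl from hydroxymethyl, so the methyl can be removed here without a shift beyond the scatter. No independent measurement is available that would explain this result.

The compounds shown leave open how this assay would read with an amine or a carboxylic acid in place of the hydroxyl, or with a longer chain carrying the hydroxyl at this position. As far as these compounds go, compound 1 differs from compound 2 and compound 3 in more than one place, so its value cannot be assigned to any single group, and the separate contributions of its cyclopropyl amide and its ethyl group remain open.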